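Working notes: from piperazin-1-yl to 3-oxomorpholin-4-yl

The source may hold more compounds than are shown below. What is called first, only, known or untested is meant among the compounds shown, and "the series" means these compounds.

In a physicochemical assay for solubility (on this read-out lower numbers stand for lower solubility and higher numbers for higher solubility), compound 1 `O=C1OCCN1c1cc(C(F)(F)F)ccc1[C@H]1CCOc2cc(S(=O)(=O)Nc3nccs3)ccc21` gives 295000 nM and compound 3 `O=S(=O)(Nc1nccs1)c1ccc2c(c1)OCC[C@@H]2c1ccc(C(F)(F)F)cc1N1CCNCC1` gives 288000 nM, two values within the scatter of each other. Compound 2 `O=S(=O)(Nc1nccs1)c1ccc2c(c1)OCC[C@@H]2c1ccc(C(F)(F)F)cc1-c1ccc(F)cc1` lies lower at 39000 nM.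

The change under review leads to compound 4 `O=C1COCCN1c1cc(C(F)(F)F)ccc1[C@H]1CCOc2cc(S(=O)(=O)Nc3nccs3)ccc21`: 3-oxomorpholin-4-yl in place of piperazin-1-yl on an aromatic carbon, ortho to a large group and meta to a trifluoromethyl group (3-oxomorpholin-4-yl in place of piperazin-1-yl on an aromatic carbon). Both groups are a six-membered non-aromatic ring with 2 hetero atoms.

All three measured steps involve this same carbon. Going from 2-oxo-1,3-oxazolidin-3-yl to piperazin-1-yl gave a 1.0-fold lower number from compound 1 to compound 3 (0.01 log units; within the scatter). The two steps involving 4-fluorophenyl were larger: a 7.6-fold lower number from compound 1 to compound 2 (0.88 log units; beyond the scatter) and a 7.4-fold higher number from compound 2 to compound 3 (0.87 log units; beyond the scatter). Compound 4 carries no 4-fluorophenyl, so the step to compound 3 from compound 1, a 1.0-fold lower number from compound 1 to compound 3 (0.01 log units; within the scatter), is the closest guide, and no step beyond the scatter is expected in this assay.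

The estimated step is a 1.2-fold lower number from compound 3 to compound 4 (0.06 log units; within the scatter). For compound 4 the expected value is 250000 nM, with an estimated range of 110000 nM to 480000 nM.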

Compound 4, solubility: 695000 nM
The estimate for compound 4 lay 2.8-fold (0.44 log units) below the measured number, and the stated range ends below it.
By their numbers in this assay, from the lowest: compound 2; then compounds 3 and 1 (each within the scatter of the next); then compound 4.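

In this assay, the non-aryl groups on this aromatic carbon, ortho to a large group and meta to a trifluoromethyl group, are no longer all level: 2-oxo-1,3-oxazolidin-3-yl and piperazin-1-yl had not separated, yet 3-oxomorpholin-4-yl gives a 2.4-fold higher number from compound 3 to compound 4 (0.38 log units; beyond the scatter) and a 2.4-fold higher number from compound 1 to compound 4 (0.37 log units; beyond the scatter). The change from the aryl group also reaches further than any earlier step, with an 18-fold higher number from compound 2 to compound 4 (1.25 log units; beyond the scatter), so compound 4 holds the highest number of the four, with its steps to all three others beyond the scatter. Nothing at hand accounts for the size of these steps.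

The compounds shown leave open whether the higher number goes with the carbonyl, the ring oxygen or the two together. Morpholin-4-yl, which lacks the carbonyl, and 2-oxopiperidin-1-yl, which lacks the ring oxygen, would separate these on the same carbon.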